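The source may report more compounds than this note shows. Statements on the series, on what has been measured and on what is new or still open speak of the compounds shown alone.

Measured so far:
- compound 1 `CCN1CCc2c(sc(NC(=O)NCC3CCCO3)c2C(N)=O)C1`: > 25000 nM, a limit of the assay
- compound 2 `CCN1CCc2c(sc(NC(=O)Nc3ccc(Cl)cc3)c2C(N)=O)C1`: 3120 nM
- compound 3 `CCN1CCc2c(sc(NC(=O)Nc3ccc(Cl)cc3)c2C#N)C1`: > 25000 nM, a limit of the assay

Among the compounds with values here, in a functional assay (strain AB) with Danio rerio as the target, read by microscopy, with a stated time of 1 h (a higher number here means that more compound is needed for the effect, a lower number that less compound is needed), compound 2 stands as the only value that is a number; the other two entries are limits. Compound 1 sits at a limit. Compound 3 sits at a limit as well. The two measured steps, an at least 8.0-fold lower number from compound 1 to compound 2 (0.90 log units; beyond the scatter) and an at least 8.0-fold higher number from compound 2 to compound 3 (0.90 log units; beyond the scatter), both run against (the limit of > 25000 nM in this assay, at which 2 of the 3 values shown sit), so their true size is open-ended.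

Compound 4 `CC(C)N1CCc2c(sc(NC(=O)Nc3ccc(Cl)cc3)c2C(N)=O)C1` differs from compound 2 by methyl in place of hydrogen on a saturated chain carbon bound to an amine nitrogen in a ring and a saturated chain carbon. The measured steps concern the amide-type nitrogen and the aromatic carbon carrying the carbamoyl, and neither touches the saturated chain carbon bound to the amine nitrogen in the ring. Nothing measured therefore bears on this change, and no step beyond the scatter is expected in this assay in either direction. Compound 4 is estimated at 3200 nM, with a range from 1200 nM to 9000 nM. The estimated step is a 1.0-fold higher number from compound 2 to compound 4 (0.01 log units; within the scatter).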

Compound 4, half-maximal effective concentration: 1490 nM
The estimate for compound 4 lay 2.1-fold (0.33 log units) above the measured number, within the range that was stated.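

In this assay, within the data shown here, ethyl to isopropyl on the amine nitrogen in a ring gives a 2.1-fold lower number from compound 2 to compound 4 (0.32 log units; beyond the scatter) and so shows that this part of the series, untouched by the earlier steps, responds to a small change. Unlike those earlier steps, which ran against a limit of the assay, this one joins two numbers and has a readable size, though only a modest one. Nothing given here speaks to what lies behind this step.

On these data alone, what a longer chain, a cyclopropyl ring or a plain amine hydrogen at this nitrogen would do remains open, so one step does not yet make a trend with chain branching. Also open, as far as these compounds go, is whether isopropyl in place of ethyl gives a similar step when nitrile stands in place of carbamoyl or another group replaces 4-chlorophenyl.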